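A few compounds are considered here, and "the series" means these few. Any claim that something is new, unique, unknown or untested is made for them only; others in the source may bear on it.

Measured in a functional assay on CFPAC-1 cells (Homo sapiens) for antiproliferative activity, read by MTT assay, with a stated time of 72 h; on this read-out higher numbers stand for weaker inhibition and lower numbers for stronger inhibition:
- Compound 1 `O=C1O/C(=C\Cn2cc(-c3ccc(Br)cc3)nn2)C(OCc2ccccc2)=C1OCc1ccccc1`: > 100000 nM, a limit of the assay
- Compound 2 `O=C1O[C@H]([C@@H](O)Cn2cc(-c3cc(C(F)(F)F)cc(C(F)(F)F)c3)nn2)C(OCc2ccccc2)=C1OCc1ccccc1`: 66500 nM
- Compound 3 `CCCCCc1ccc(-c2cn(C[C@H](O)[C@H]3OC(=O)C(OCc4ccccc4)=C3OCc3ccccc3)nn2)cc1`: 9890 nM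

Compound 1 reports only a limit, > 100000 nM. Of the two actual numbers, compound 3 has the lower at 9890 nM, and the gap to compound 2 at 66500 nM lies beyond the scatter.

Compound 4 `CC(C)(C)c1cn(C[C@H](O)[C@H]2OC(=O)C(OCc3ccccc3)=C2OCc2ccccc2)nn1` has not yet been measured in this assay. It differs from compound 3 by tert-butyl in place of 4-pentylphenyl on an aromatic carbon. For the measured compounds named here, no measured pair isolates this change, so any forecast is tentative. Going by the values given here, the expectation rests on compound 3, whose 9890 nM is the only value here obtained with the 4-pentylphenyl group, which is lost in the change. Weaker inhibition is therefore expected, by a margin beyond the scatter. The estimated change is a 4.0-fold higher number from compound 3 to compound 4 (0.61 log units; beyond the scatter). For compound 4 the expected value is 40000 nM, with an estimated range of 12000 nM to 100000 nM.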

Compound 4, half-maximal inhibitory concentration: 54900 nM
Compound 4: the middle estimate sits 1.4-fold (0.14 log units) below what was measured; low and high end bracket the measured number.
By their numbers in this assay, from the lowest: compound 3; then compounds 4 and 2 (each within the scatter of the next). At a limit, above all of these: compound 1.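

In this assay, the aromatic carbon of the five-membered aromatic ring with 3 nitrogen now has its first isolated change: tert-butyl in place of 4-pentylphenyl gives a 5.6-fold higher number from compound 3 to compound 4 (0.74 log units; beyond the scatter). This single pair ties the lower number to the 4-pentylphenyl group, although the smaller tert-butyl, with no ring, still leaves a measurable number. Only compound 1 sits at a limit of the assay, so this step is read between two actual numbers: the limit of > 100000 nM in this assay, at which 1 of the 4 values shown sits.

The compounds shown leave open whether the ring or the pentyl chain accounts for the step, which an unsubstituted phenyl or a bare pentyl chain at this position would separate. From the compounds shown here alone, how an amine or a carboxylic acid at the same place would read also remains open.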